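Enlarging the Amine on a Dithiocarbamate Ester

A few compounds are considered here, and "the series" means these few. Any claim that something is new, unique, unknown or untested is made for them only; others in the source may bear on it.

Compound 1, `CCN(CC)C(=S)SCC1=CCOC1=O`, gives 1390 nM in a functional assay on HeLa cells (Homo sapiens) for antiproliferative activity, read by MTT assay, with a stated time of 72 h; a lower number here means a stronger inhibitor, a higher number a weaker inhibitor.
Compound 2, `CN(C)C(=S)SCC1=CCOC1=O`, gives 114000 nM in this assay.
Compound 3, `O=C1CC2(CO1)CSC(=S)N2C1CC1`, gives 28700 nM in this assay.

Compound 2 stands highest of the three numbers, so it is the weakest inhibitor here; compound 3 lies nearest to it, compound 1 furthest. Compound 4, `O=C1OCC=C1CSC(=S)N1CCCC1`, differs from compound 2 by pyrrolidin-1-yl in place of dimethylamino on a thiocarbonyl carbon. Within the data shown here, the one measured step that bears on this change is an 82-fold higher number from compound 1 to compound 2 (1.91 log units; beyond the scatter): trimming the amine weakened the compound greatly. Closing the amine into a five-membered ring goes the other way, so a clearly lower number is expected for compound 4 in this assay, though not necessarily all the way back to compound 1. Compound 4 is therefore estimated at 5000 nM, within 900 nM to 28000 nM, an expected step of a 23-fold lower number from compound 2 to compound 4 (1.36 log units; beyond the scatter).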

Compound 4, half-maximal inhibitory concentration: 2630 nM
Beside the measured number, compound 4's estimate is 1.9-fold (0.28 log units) above it; measured number inside the range.
By their numbers in this assay, from the lowest: compounds 1 and 4 (each within the scatter of the next); then compound 3; then compound 2.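

In this assay, the size of the amine alone does not set the result: pyrrolidin-1-yl in place of dimethylamino on a thiocarbonyl carbon gives a 43-fold lower number from compound 2 to compound 4 (1.64 log units; beyond the scatter), a large step. Pyrrolidin-1-yl in place of diethylamino gives a 1.9-fold higher number from compound 1 to compound 4 (0.28 log units; within the scatter), so a closed ring and an open amine with two ethyl arms perform alike at this position. The compounds shown leave open whether a larger ring, such as piperidin-1-yl or morpholin-4-yl, would hold this level. Nothing given here explains why these amines differ.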